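From Isobutylamino to Hydroxy in Compound 3

The source may report more compounds than this note shows. Statements on the series, on what has been measured and on what is new or still open speak of the compounds shown alone.

Of the compounds shown here, three have been tested in a functional assay for inhibition, with Rattus norvegicus as the target, at pH 7.35; a lower number here means a stronger inhibitor, a higher number a weaker inhibitor. Compound 1 `CCOC(=O)C(=O)C(CC)NC(=O)C(CC(C)C)NC(=O)OCC(C)C` reaches only a limit, > 300000 nM. Compound 2 `CCCCC(NC(=O)C(CC(C)C)NC(=O)OCc1ccccc1)C(=O)C(=O)OCC` gives 150000 nM. Compound 3 `CCC(NC(=O)C(CC(C)C)NC(=O)OCc1ccccc1)C(=O)C(=O)NCC(C)C` gives 28000 nM, the lower of the two exact numbers and a gap beyond the scatter. Compound 4 `CCC(NC(=O)C(CC(C)C)NC(=O)OCc1ccccc1)C(=O)C(=O)O` carries hydroxy in place of isobutylamino on a carbonyl carbon. For the measured compounds named here, no measured step isolates this change, so its size in this assay remains uncertain. Going by the values given here, compound 3, at 28000 nM, is the only tested compound holding isobutylamino, so a move towards weaker inhibition is expected, roughly to the level of compound 2 at 150000 nM. The expected step is a 3.6-fold higher number from compound 3 to compound 4 (0.55 log units; beyond the scatter). The estimated value for compound 4 is 100000 nM, with an expected range of 25000 nM to 300000 nM.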

Compound 4, half-maximal inhibitory concentration: 100000 nM
The estimate for compound 4 equals the measured number at the digits printed, and the stated range covers the measured number.
By their numbers in this assay, from the lowest: compound 3; then compounds 4 and 2 (each within the scatter of the next). At a limit, above all of these: compound 1.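

In this assay, for the compounds shown here, the only step read at this place, on a carbonyl carbon, is a 3.6-fold higher number from compound 3 to compound 4 (0.55 log units; beyond the scatter), so hydroxy in place of isobutylamino weakens inhibition modestly without abolishing it. Compound 4 still gives an exact number. Compound 1 alone stands at a limit of the assay: the limit of > 300000 nM in this assay, at which 1 of the 4 values shown sits.

Going by these compounds, whether a benzylamino or morpholino group here would read closer to compound 3 or to compound 4 stays open. This single step also leaves open whether the exchange would have the same size with a longer chain on the shared core.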